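A few compounds are considered here, and "the series" means these few. Any claim that something is new, unique, unknown or untested is made for them only; others in the source may bear on it.

Compound 1 `COc1ccc(Cc2nnc(CN(c3cccc(C(F)(F)F)c3C)S(=O)(=O)c3ccc(C)cc3)o2)cc1`: 398 nM
Compound 2 `Cc1ccc(S(=O)(=O)N(Cc2nnc(Cc3ccc(C(F)(F)F)cc3)o2)c2cccc(Cl)c2C)cc1`: 158 nM
Compound 3 `CCOc1ccc(Cc2nnc(CN(c3cccc(Cl)c3Cl)S(=O)(=O)c3ccc(C(F)(F)F)cc3)o2)cc1`: 6.31 nM

In a functional assay on CHO cells for antagonist activity at prostaglandin E2 receptor EP1 subtype (Homo sapiens), read by FLIPR and calcium flux (a higher number here means a weaker inhibitor, a lower number a stronger inhibitor), compound 2 gives 158 nM, the second highest of the three numbers. Compound 1, with 398 nM, stands nearest to it; compound 3, with 6.31 nM, stands furthest away, and both gaps lie beyond the scatter. Compound 4 `COc1ccc(Nc2nnc(CN(c3cccc(Cl)c3C)S(=O)(=O)c3ccc(C)cc3)o2)cc1` differs from compound 2 in one place: (4-methoxyphenyl)amino in place of 4-(trifluoromethyl)benzyl on an aromatic carbon. Within the data shown here, no measured pair shows a change of this kind, so its size is not known from the data. A modest rise of the number is expected, plausibly beyond the scatter, though a result within it is also possible. For compound 4 the estimate is 250 nM, with a range from 60 nM to 1000 nM. The step expected from compound 2 to compound 4 is a 1.6-fold higher number from compound 2 to compound 4 (0.20 log units; within the scatter).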

Compound 4, inhibition constant: 79.4 nM
For compound 4 the middle estimate is 3.1-fold (0.50 log units) above the measured one, within the range that was stated.
By their numbers in this assay, from the lowest: compound 3; then compounds 4 and 2 (each within the scatter of the next); then compound 1.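

In this assay, among these compounds, the first comparison that differs in one place shows that (4-methoxyphenyl)amino in place of 4-(trifluoromethyl)benzyl on this aromatic carbon gives a 2.0-fold lower number from compound 2 to compound 4 (0.30 log units; within the scatter). The two groups are therefore not told apart here, even though the entering group brings a hydrogen-bond donor and acceptors that the leaving group lacks. Nothing measured accounts for this result. Going by these compounds, it remains open how a morpholine, a carboxylic acid or a longer alkyl chain would read on this carbon. The pair also does not separate the contribution of the amino link from that of the methoxy group.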